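The source may hold more compounds than are shown below. What is called first, only, known or untested is meant among the compounds shown, and "the series" means these compounds.

Working notes on the series, read in an ADME assay on L02 cells (Homo sapiens) for inhibition, read by CCK-8 assay, with a stated time of 48 h; on this read-out lower numbers stand for stronger inhibition of growth and higher numbers for weaker inhibition of growth. Compound 1 `Cc1ccc(Nc2ncc(Cl)c(Nc3ccccc3C)n2)cc1` gives > 100000 nM, and this is a limit of the assay, not a number. Among the compounds with values here, compound 2 `CN1CCN(c2ccc(Nc3ncc(Cl)c(NCc4ccccc4)n3)nc2)CC1` gives 20300 nM, the only true number so far. The next compound is compound 3 `COc1ccccc1CNc1nc(Nc2ccc(N3CCN(C)CC3)cn2)ncc1Cl`, which differs from compound 2 in one place: methoxy in place of hydrogen on an aromatic carbon. This is methoxy in place of hydrogen on an aromatic carbon, ortho to a large group, so that benzylamino becomes (2-methoxybenzyl)amino. Within the data shown here, the series has no measured step between compounds that differ in one place, so nothing yet sizes such a change in this assay. Compound 2 at 20300 nM is the sole anchor, so only a small move is expected from this single change. The estimated 1.3-fold lower number from compound 2 to compound 3 (0.10 log units; within the scatter) is a slight shift toward stronger inhibition of growth, and it is expected to stay close to the usual scatter. The expected value for compound 3 is 16000 nM, with an estimated range from 5000 nM to 50000 nM.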

Compound 3, concentration for 50% growth inhibition: 25500 nM
Compound 3: middle estimate off by 1.6-fold (0.20 log units), on the low side; the range from low to high includes it.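

In this assay, the series now has its first measured step between compounds that differ in one place, with a 1.3-fold higher number from compound 2 to compound 3 (0.10 log units; within the scatter) for methoxy in place of hydrogen on an aromatic carbon, ortho to a large group. At this place, therefore, going from benzylamino to (2-methoxybenzyl)amino adds a group of 2 heavy atoms without separating the two compounds beyond the usual scatter, and one such pair shows no more than that. Compound 1 gives a limit of the assay and not a number, so no step can be read from it: the limit of > 100000 nM in this assay, at which 1 of the 3 values shown sits.

The compounds shown leave open whether another group on this same aromatic carbon, such as a fluorine, an amine or a carboxylic acid, would give a step beyond the scatter, or whether methoxy on a different carbon of the ring would. They also leave open whether a longer chain in place of the benzyl link, or a change elsewhere on the shared core, would move the number in this assay at all.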